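This account rests on a few compounds, and the source may have more. Where it says the series, first, only, none or still open, it means among the compounds named here.

In a physicochemical assay for solubility, read by spectrophotometry, in phosphate buffer, with a stated time of 18 h, at pH 7.4 (a higher number here means a more soluble compound, a lower number a less soluble compound), compound 1 `CCc1ccc(-c2nc3c(c(C)nn3-c3ccccc3)c(-c3ccccc3O)c2C#N)cc1` gives 3100 nM, and compound 2 `Cc1nn(-c2ccccc2)c2nc(-c3ccc4ccccc4c3)c(C#N)c(-c3ccccc3O)c12` gives 1800 nM. Among the measured compounds shown here, compound 2 therefore stands level with compound 1, the only other compound measured so far, since the two numbers lie within the usual scatter of each other. Compound 3 `Cc1nn(-c2ccccc2)c2nc(-c3ccc(Cl)cc3)c(C#N)c(-c3ccccc3O)c12` differs from compound 2 at one place, with 4-chlorophenyl in place of naphthalen-2-yl on an aromatic carbon. For the measured compounds named here, the one measured step at that same carbon is a 1.7-fold lower number from compound 1 to compound 2 (0.24 log units; within the scatter), and it replaced 4-ethylphenyl with naphthalen-2-yl. That single step is thin evidence, but it gives no reason to expect a change beyond the scatter in this assay. The expected size of the change is a 1.3-fold higher number from compound 2 to compound 3 (0.12 log units; within the scatter). For compound 3, the estimated solubility is 2400 nM, with an expected range from 1000 nM to 5500 nM.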

Compound 3, solubility: 3800 nM
For compound 3 the middle estimate is 1.6-fold (0.20 log units) below the measured one; measured number inside the range.
By their numbers in this assay, from the lowest: compounds 2, 1 and 3 (each within the scatter of the next, the first and the last beyond it).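

In this assay, among the compounds shown here, the step of a 2.1-fold higher number from compound 2 to compound 3 (0.32 log units; beyond the scatter) is the first at this aromatic carbon next to the ring nitrogen to pass beyond the scatter, though only modestly, so the group held there can matter for this read-out. The other new step, a 1.2-fold higher number from compound 1 to compound 3 (0.09 log units; within the scatter), shows that chloro and ethyl on the phenyl ring stand level, yet the two-ring naphthalen-2-yl group does not set a clean divide, since compound 2 lies beyond the scatter of compound 3 but within that of compound 1. No measurement offers a reason for the difference between compound 2 and compound 3. As far as these compounds go, whether an amine or a carboxylic acid on that phenyl ring would shift the number further remains open. So does whether a nitrogen-containing ring such as pyridine would behave like these all-carbon rings at this position.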